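The compounds below may be only part of what the source reports. "The series", "measured", "known", "first", "only" and "open" are said of these compounds alone.

In a functional assay on the whole organism with Mus musculus as the target, at a dose of 100 mg/kg by the intraperitoneal route (on this read-out lower numbers stand for less inhibition and higher numbers for more inhibition at the one dose given (going by the name of the read-out)), three compounds have been measured: compound 1 `CCN(C)C(=O)/C=C1\CCc2c(F)cc(F)cc21` gives 100%; compound 2 `O=C(/C=C1\CCc2c(F)cc(F)cc21)NC1CC1` gives 100%; compound 3 `O=C(/C=C1\CCc2c(F)cccc21)NC1CC1` gives 100%.

Compound 2 stands level with compounds 1 and 3 at the digits shown. Two steps lead through it. The first, no change at the digits printed from compound 1 to compound 2 (within the scatter), replaced ethyl(methyl)amino with cyclopropylamino on a carbonyl carbon and left the read-out where it was. The second, no change at the digits printed from compound 2 to compound 3 (within the scatter), exchanged a fluoro for hydrogen on an aromatic carbon and again moved nothing beyond the scatter.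

Compound 4 `CC(C)NC(=O)/C=C1\CCc2c(F)cc(F)cc21` differs from compound 2 in one place: isopropyl in place of cyclopropyl on an amide-type nitrogen. The step from compound 1 to compound 2 bears most directly on this change, since it also altered the group carried on the amide-type nitrogen, and it produced no shift. The step from compound 2 to compound 3 touched a different part of the molecule and was equally flat. Within the data shown here, every measured compound already sits at the top of the scale of this read-out, so a higher number is not available; no step in this set was beyond the scatter, and none is expected here.

Compound 4 is therefore expected to give 100%, within a range of 85% to 100%. The estimated step is no change at the digits printed from compound 2 to compound 4 (within the scatter), expected to lie within the scatter.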

Compound 4, a percentage reported as inhibition, in the whole organism at one dose (the size of the read-out at that dose, not a potency): 100%
Estimate against measurement, compound 4: no gap at the digits printed, within the range that was stated.
By their numbers in this assay, from the lowest: compounds 1, 2, 3 and 4 (each within the scatter of the next).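

In this assay, isopropyl in place of cyclopropyl on the amide-type nitrogen gives no change at the digits printed from compound 2 to compound 4 (within the scatter), so the three-membered ring is not needed at this place for the full read-out at this dose. Isopropylamino in place of ethyl(methyl)amino on the carbonyl carbon gives no change at the digits printed from compound 1 to compound 4 (within the scatter), which adds a second comparison at this place in which the group on the nitrogen carries no ring. No measurement at hand offers an explanation for these flat steps.

All the compounds shown sit at the top of the scale, so any difference among them that this single dose cannot reveal remains hidden. From the compounds shown here alone, it also remains open whether a benzyl group or a longer chain ending in a carboxylic acid on the amide-type nitrogen would hold the read-out at that level.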